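The source may report more compounds than this note shows. Statements on the series, on what has been measured and on what is new or still open speak of the compounds shown alone.

Measured in a functional assay on MCF7 cells (Homo sapiens) for inhibition, read by MTT assay, with a stated time of 72 h; on this read-out higher numbers stand for weaker inhibition and lower numbers for stronger inhibition:
compound 1 `CC(C)[C@H](NC(=O)c1cc(Cl)ccc1OCCN)C(=O)Nc1ccc([N+](=O)[O-])cc1Cl`: > 10000 nM
compound 2 `CC(C)[C@H](NC(=O)c1cc(Cl)ccc1OCCNC(=O)OC(C)(C)C)C(=O)Nc1ccc(F)c(F)c1`: > 10000 nM

Both entries are limits of the assay and not numbers. Compound 2 stands only at a limit, > 10000 nM. Compound 3 `CC(C)[C@H](NC(=O)c1cc(Cl)ccc1OCCN)C(=O)Nc1ccc(F)c(F)c1` differs from compound 2 by hydrogen in place of tert-butoxycarbonyl on an amine nitrogen. Within the data shown here, no measured step is available in this assay. Compound 1, which also carries the 2-aminoethyl chain, gives > 10000 nM, again a limit. No shift beyond the scatter is therefore expected, and the estimated a number no higher from compound 2 to compound 3 (the limit leaves the size open) has no clear direction. For compound 3 the estimate is 10000 nM, with an expected range of 3000 nM to 30000 nM.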

Compound 3, half-maximal inhibitory concentration: > 10000 nM
Compound 3: a limit, no number; the forecaster's own chance of this, stated with the estimate: 70%; the middle value sits exactly at the limit.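

In this assay compound 3 gives > 10000 nM, a limit, and the steps to compound 3 from compound 1 and from compound 2 cannot be read: the limit of > 10000 nM in this assay, at which 3 of the 3 values shown sit.

The compounds shown leave open what readable value any of the three has, and how far either change shifts inhibition.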